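The source may hold more compounds than are shown below. What is called first, only, known or untested is meant among the compounds shown, and "the series" means these compounds.

In an ADME assay on MRC5 cells (Homo sapiens) for inhibition, with a stated time of 72 h (a higher number here means that more compound is needed for the effect, a lower number that less compound is needed), compound 1 `COc1cccc(OC)c1C(=O)Nc1c[nH]nc1C(=O)N[C@H]1CC[C@H](O)CC1` gives 34000 nM. Compound 2 `COc1cccc(OC)c1C(=O)Nc1c[nH]nc1C(=O)O` has no exact number, only a limit of > 50000 nM, and the limit of > 50000 nM in this assay, at which 1 of the 2 values shown sits, marks that limit. Compound 3 `COc1cccc(OC)c1C(=O)Nc1c[nH]nc1C(=O)NCc1ccccc1` differs from compound 2 by benzylamino in place of hydroxy on a carbonyl carbon, with benzylamino in place of hydroxy on a carbonyl carbon. For the measured compounds named here, the one measured step at this carbon runs from an amide to the acid, with hydroxy in place of (4-hydroxycyclohexyl)amino, and it is an at least 1.4-fold higher number from compound 1 to compound 2 (0.16 log units; that floor lies within the scatter). A small move toward a lower number is therefore expected, estimated as an at least 1.6-fold lower number from compound 2 to compound 3 (0.22 log units; that floor lies within the scatter). Compound 3 is expected at 30000 nM, with an estimated range of 12000 nM to 50000 nM.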

Compound 3, half-maximal effective concentration: 50000 nM
The estimate for compound 3 lay 1.7-fold (0.22 log units) below the measured number; low and high end bracket the measured number.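

In this assay, benzyl in place of 4-hydroxycyclohexyl on the amide-type nitrogen gives a 1.5-fold higher number from compound 1 to compound 3 (0.17 log units; within the scatter), so the two amides cannot be told apart at this position. Benzylamino in place of hydroxy on the carbonyl carbon gives a number no higher from compound 2 to compound 3 (the limit leaves the size open) and the size of this step cannot be read because compound 2 stands only at a limit of the assay: the limit of > 50000 nM in this assay, at which 1 of the 3 values shown sits.

As far as these compounds go, the exact size of the step from the acid to either amide stays open.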